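Salicylanilide amines: hydroxypropyl pair replacing fluorobenzylamino

The source may hold more compounds than are shown below. What is called first, only, known or untested is meant among the compounds shown, and "the series" means these compounds.

Compound 3 `O=C(Nc1ccc(NCc2ccc(F)cc2)cc1Cl)c1cc(Cl)ccc1O` stands second highest of the three numbers in an ADME assay on A549 cells (Homo sapiens) for cytotoxicity, read by resazurin assay, with a stated time of 48 h (a higher number here means that more compound is tolerated, a lower number that less compound is tolerated), with 54400 nM; its nearest neighbour is compound 1 `O=C(Nc1ccc(NC2CCCCC2)cc1Cl)c1cc(Cl)ccc1O`, at 68300 nM, and the furthest is compound 2 `O=C(Nc1ccc(N(CC2CC2)CC2CC2)cc1Cl)c1cc(Cl)ccc1O`, at 12800 nM. Compound 4 `O=C(Nc1ccc(N(CCCO)CCCO)cc1Cl)c1cc(Cl)ccc1O` is not yet measured. The change is bis(3-hydroxypropyl)amino in place of (4-fluorobenzyl)amino on an aromatic carbon.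

Among the measured compounds shown here, two measured steps bear on it. Going from a secondary amine to a tertiary one with two small chains gave a 5.3-fold lower number from compound 1 to compound 2 (0.73 log units; beyond the scatter), and the reverse kind of change gave a 4.3-fold higher number from compound 2 to compound 3 (0.63 log units; beyond the scatter). The swap between two secondary amines gave a 1.3-fold lower number from compound 1 to compound 3 (0.10 log units; within the scatter). Compound 4 carries a tertiary amine with two chains, as compound 2 does, so a modest step toward a lower number in this assay is expected, though the two chains differ from those of compound 2 and the size of the step is uncertain.

For compound 4 the expected step is a 1.7-fold lower number from compound 3 to compound 4 (0.23 log units; within the scatter). Compound 4 is therefore estimated at 32000 nM, within 11000 nM to 95000 nM.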

Compound 4, half-maximal cytotoxic concentration: 114000 nM
Beside the measured number, compound 4's estimate is 3.6-fold (0.55 log units) below it, outside the stated range (above it).
By their numbers in this assay, from the lowest: compound 2; then compounds 3, 1 and 4 (each within the scatter of the next, the first and the last beyond it).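

At this position a tertiary amine does not by itself bring a lower number in this assay: with two chains on the nitrogen in both compounds, the bis(3-hydroxypropyl)amino group gives an 8.9-fold higher number from compound 2 to compound 4 (0.95 log units; beyond the scatter), so the identity of the chains matters, and only compound 2 keeps the low number. Replacing (4-fluorobenzyl)amino with a group of the same heavy-atom count, but with no ring and with more hydrogen-bond donors and acceptors, gives a 2.1-fold higher number from compound 3 to compound 4 (0.32 log units; beyond the scatter). Against the cyclohexylamino group the result is a 1.7-fold higher number from compound 1 to compound 4 (0.22 log units; within the scatter), which lies within the scatter, so compound 1 and compound 4 are not separated here.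

No measurement at hand accounts for these differences. On these data alone, it remains open whether the hydroxyl ends or the chain length drive the result, which bis(3-methoxypropyl)amino and bis(2-hydroxyethyl)amino groups would help separate.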